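From compound 3 to compound 4: one group exchanged

The source may hold more compounds than are shown below. What is called first, only, known or untested is meant among the compounds shown, and "the series" means these compounds.

In an ADME assay for permeability, using PAMPA, with a stated time of 30 min, at pH 7.4 (on this read-out lower numbers stand for lower permeability and higher numbers for higher permeability), compound 1 (`COc1cccc(CNCCCNc2ccnc3cc(-c4ccc(F)cc4)ccc23)c1O`) gives 237 10^-6 cm/s, compound 2 (`COc1cccc(CNCCCNc2ccnc3cc(-c4ccc(C(C)(C)C)cc4)ccc23)c1O`) gives 237 10^-6 cm/s and compound 3 (`COc1cccc(CNCCCNc2ccnc3cc(Oc4cccc(N(C)C)c4)ccc23)c1O`) gives 317 10^-6 cm/s. These three numbers lie within the scatter of one another, so compound 3 does not stand apart from the other two. Compound 4 (`COc1cccc(CNCCCNc2ccnc3cc(Oc4ccc(C(C)(C)C)cc4)ccc23)c1O`) keeps the shared core and changes one group: 4-(tert-butyl)phenyl in place of 3-(dimethylamino)phenyl on an oxygen on an aromatic ring. In words, 4-(tert-butyl)phenyl takes the place of 3-(dimethylamino)phenyl on an oxygen on an aromatic ring.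

Among the compounds with values here, three measured steps bear on this change. Putting tert-butyl in place of fluoro gave no change at the digits printed from compound 1 to compound 2 (within the scatter). Putting 3-(dimethylamino)phenoxy in place of 4-fluorophenyl gave a 1.3-fold higher number from compound 1 to compound 3 (0.13 log units; within the scatter), and putting it in place of 4-(tert-butyl)phenyl gave a 1.3-fold higher number from compound 2 to compound 3 (0.13 log units; within the scatter). All three stayed within the scatter, although the groups exchanged look quite different. Within the data shown here, no measured compound yet carries 4-(tert-butyl)phenyl on the oxygen, so this remains an extrapolation. No step beyond the scatter is therefore expected in this assay, and the estimated step is a 1.2-fold lower number from compound 3 to compound 4 (0.07 log units; within the scatter). For compound 4 the expected value is 270 10^-6 cm/s. The estimated range for compound 4 runs from 140 10^-6 cm/s to 480 10^-6 cm/s.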

Compound 4, apparent permeability: 317 10^-6 cm/s
Compound 4: the middle estimate sits 1.2-fold (0.07 log units) below what was measured; low and high end bracket the measured number.
By their numbers in this assay, from the lowest: compounds 1, 2, 3 and 4 (each within the scatter of the next).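

In this assay, within the data shown here, exchanging the group on the oxygen itself gave no change at the digits printed from compound 3 to compound 4 (within the scatter) even though a group with 1 hydrogen-bond acceptor and a nitrogen gave way to an all-carbon group with 0, and no earlier pair had varied this group with the oxygen held in place. Among these compounds, compound 4 also allows the first comparison in which the same 4-(tert-butyl)phenyl ring is present with and without the oxygen: 4-(tert-butyl)phenoxy in place of 4-(tert-butyl)phenyl gave a 1.3-fold higher number from compound 2 to compound 4 (0.13 log units; within the scatter) and, measured against the fluoro compound, gave a 1.3-fold higher number from compound 1 to compound 4 (0.13 log units; within the scatter) in the same assay. So at this position neither the oxygen nor the exchange of these two substituted phenyl groups moved the number beyond the scatter, and nothing shown accounts for that result.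

From the compounds shown here alone, all the groups compared here at this position are built on a six-membered aromatic ring of carbon only, so it remains open whether a ring bearing a carboxylic acid or a primary amine would also stay within the scatter. The chain shared by all four compounds is also constant, which leaves the effect of a longer chain unknown.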